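The source may hold more compounds than are shown below. What is called first, only, known or untested is meant among the compounds shown, and "the series" means these compounds.

In an ADME assay for permeability, using PAMPA, with a stated time of 4 h, at pH 7.4, tested at 100 uM (a higher number here means that the compound crosses the layer faster, a lower number that the compound crosses the layer more slowly), compound 2 `Cc1nc2cc(-c3cccc(-c4ccccc4)c3)nn2c(-c2cc(F)c3c(c2C)CCCO3)c1[C@H](OC(C)(C)C)C(=O)O` gives 733 nm/s. Compound 3 `Cc1nc2cc(-c3cccc(-c4ccccc4)c3)nn2c(-c2cc(F)c3c(c2C)CCCO3)c1C(OC(C)(C)C)C(=O)O` gives 652 nm/s, and the step between them is a 1.1-fold lower number from compound 2 to compound 3 (0.05 log units; within the scatter). Going by the values given here, the only difference between that pair is the fact that one of compounds 2 and 3 is drawn with a defined configuration and the other without, at the place where they differ. Compound 1 `Cc1nc2cc(-c3ccc(OCc4ccccc4)cc3)nn2c(-c2cc(F)c3c(c2C)CCCO3)c1C(OC(C)(C)C)C(=O)O` gives 313 nm/s, a gap from compound 2 that lies beyond the scatter.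

Compound 4 `Cc1nc2cc(-c3cccc(-c4ccncc4)c3)nn2c(-c2cc(F)c3c(c2C)CCCO3)c1[C@H](OC(C)(C)C)C(=O)O` is reached from compound 2 by one change, pyridin-4-yl in place of phenyl on an aromatic carbon. The new ring brings a hydrogen-bond acceptor where the old ring had none. Among the compounds with values here, the single measured step, a 1.1-fold lower number from compound 2 to compound 3 (0.05 log units; within the scatter), concerns only how a stereocentre is drawn, so it says nothing about this swap. Within the data shown here, no measured step shows what this swap does, which leaves the direction a cautious judgement. Compound 1 at 313 nm/s shows that numbers well under that of compound 2 occur in this small set. A moderate fall is expected, with an estimated size of a 2.2-fold lower number from compound 2 to compound 4 (0.35 log units; beyond the scatter). For compound 4 the estimated value is 330 nm/s, with an expected range from 130 nm/s to 700 nm/s.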

Compound 4, apparent permeability: 488 nm/s
Compound 4: the middle estimate sits 1.5-fold (0.17 log units) below what was measured; the measured number falls inside the stated range.
By their numbers in this assay, from the lowest: compounds 1, 4, 3 and 2 (each within the scatter of the next, the first and the last beyond it).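

In this assay, putting pyridin-4-yl in place of phenyl on this aromatic carbon, meta to a large group, gives a 1.5-fold lower number from compound 2 to compound 4 (0.18 log units; within the scatter). Going by these compounds alone, the only earlier step concerned how a stereocentre is drawn, so this is the first reading of a change to the outer ring, and it shows that this ring can carry a nitrogen and a hydrogen-bond acceptor with a step no larger than the usual scatter. Nothing measured in this set speaks to why the step has this size.

The compounds shown leave open how a pyridin-3-yl or pyrimidin-5-yl ring would read here, or a phenyl ring carrying an amine or a carboxylic acid. Going by these compounds, this swap also rests on one pair, so its reading on other members remains unknown.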